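Hydroxy to Nitro Exchange on Two Related Cores

This account rests on a few compounds, and the source may have more. Where it says the series, first, only, none or still open, it means among the compounds named here.

Compound 1 `COc1ccc(-c2cnnn2Cc2cc(OC)c(OC)c(OC)c2)cc1O` is the reference point. In a functional assay on K562 cells (Homo sapiens) for cytotoxicity, read by MTT assay, with a stated time of 5 days (a lower number here means a stronger inhibitor, a higher number a weaker inhibitor), compound 1 gives 530 nM. Compound 2 `COc1ccc(-c2cnnn2Cc2cc(OC)c(OC)c(OC)c2)cc1[N+](=O)[O-]` differs from it by one change, (nitro in place of hydroxy on an aromatic carbon). For compound 2 the reading in this assay is only a limit, > 10000 nM. The step is an at least 18-fold higher number from compound 1 to compound 2 (1.27 log units; beyond the scatter), which sits at the limit of > 10000 nM in this assay, at which 2 of the 3 values shown sit.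

Compound 3 `COc1ccc(-c2cn(-c3cc(OC)c(OC)c(OC)c3)nn2)cc1O` is built on another core; how the two cores differ is not broken down here. For compound 3 the reading in this assay is again only a limit, > 10000 nM. Compound 4 `COc1ccc(-c2cn(-c3cc(OC)c(OC)c(OC)c3)nn2)cc1[N+](=O)[O-]`, not yet measured, carries the same change relative to compound 3, (nitro in place of hydroxy on an aromatic carbon), at a place described in the same words as for compound 2.

On the core of compound 1 the change gave an at least 18-fold higher number from compound 1 to compound 2 (1.27 log units; beyond the scatter). The step from compound 3 to compound 4 in this assay is expected to be a step that the limit leaves unreadable from compound 3 to compound 4, since the number is not expected to come down. That expectation rests on compound 3, whose reading is a limit, > 10000 nM. Compound 4 is therefore estimated at 20000 nM in this assay, within a range from 8000 nM to 60000 nM, most probably reported as a limit once more.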

Compound 4, half-maximal inhibitory concentration: > 10000 nM
Compound 4 was reported as a limit; the forecaster's own chance of this, stated with the estimate: 90%; the middle value is on the limit's open side.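

In this assay, compound 3 and compound 4 both stand at a limit rather than at a number, so no step between them can be read: the limit of > 10000 nM in this assay, at which 3 of the 4 values shown sit.

The compounds shown leave open whether nitro in place of hydroxy changes the reading at all on the core of compound 3, and whether it does so as on the core of compound 1.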